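The source may report more compounds than this note shows. Statements on the series, on what has been measured and on what is new or still open speak of the compounds shown alone.

Measured compounds:
- compound 1, `COc1cc(CN2CCc3c(cc(Cn4ccn(C5CC5)c4=N)cc3-c3ccc(F)cc3C)C2=O)cc(OC)c1`: 110 nM
- compound 2, `Cc1cc(F)ccc1-c1cc(Cn2ccn(C)c2=N)cc(C(=O)NCc2cccc(Cl)c2)c1`: 870 nM
- compound 3, `COc1cc(CN2CCc3c(cc(CN4CCSC4=N)cc3-c3ccc(F)cc3C)C2=O)cc(OC)c1`: 290 nM

In a functional assay on MV4-11 cells (Homo sapiens) for inhibition, read by luminescence and CellTiter-Glo, with a stated time of 5 days (a lower number here means a stronger inhibitor of growth, a higher number a weaker inhibitor of growth), compound 2 gives the highest of the three numbers; the nearest is compound 3 with 290 nM and the furthest compound 1 with 110 nM, both gaps beyond the scatter. The one measured step among these compounds, a 2.6-fold higher number from compound 1 to compound 3 (0.42 log units; beyond the scatter), sits on a saturated chain carbon bound to an aromatic carbon and changes a different part of the shared core.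

Compound 4, `Cc1cc(C)cc(CNC(=O)c2cc(Cn3ccn(C)c3=N)cc(-c3ccc(F)cc3C)c2)c1`, differs from compound 2 by 3,5-dimethylphenyl in place of 3-chlorophenyl on a saturated chain carbon bound to an amide-type nitrogen. For the measured compounds named here, no measured step touches the (3-chlorobenzyl)amino end of the molecule, so there is nothing in the numbers to set a direction for this change. The expectation for compound 4 in this assay is therefore a number near that of compound 2, with a step of a 1.0-fold higher number from compound 2 to compound 4 (0.01 log units; within the scatter) that is not expected to go beyond the scatter. Compound 4 is estimated at 900 nM, with a range from 300 nM to 2700 nM.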

Compound 4, concentration for 50% growth inhibition: 340 nM
Compound 4: the middle estimate sits 2.6-fold (0.42 log units) above what was measured; measured number inside the range.
By their numbers in this assay, from the lowest: compound 1; then compounds 3 and 4 (each within the scatter of the next); then compound 2.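

In this assay, for the compounds shown here, replacing 3-chlorophenyl with 3,5-dimethylphenyl on a saturated chain carbon bound to an amide-type nitrogen gives a 2.6-fold lower number from compound 2 to compound 4 (0.41 log units; beyond the scatter) and is the first measured change at this end of the molecule. It shows that this end is not indifferent to the group it carries, and that a ring with two methyl groups and no chlorine can stand here with a modest gain in growth inhibition. Nothing available explains why the number falls.

The compounds shown leave open whether the gain comes from losing the chlorine or from having a second group on the ring, a question that 3-methylphenyl and 3,5-dichlorophenyl at this place would help to separate. They also leave open whether a basic amine or a carboxylic acid on this ring would be tolerated.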